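Replacing 2-methylphenyl with 4-chlorophenyl on the shared core

This account rests on a few compounds, and the source may have more. Where it says the series, first, only, none or still open, it means among the compounds named here.

Of the compounds shown here, three have been measured in an ADME assay on Vero 76 cells (Chlorocebus sabaeus) for cytotoxicity, read by MTT assay, with a stated time of 96 h; a higher number here means that more compound is tolerated, a lower number that less compound is tolerated. Compound 1 (`NS(=O)(=O)c1ccc(N2N=C(c3ccccc3)CC2c2ccccc2F)cc1`) gives 28000 nM, compound 3 (`Cc1cccc(C2CC(c3ccc(Oc4ccccc4)cc3)=NN2c2ccc(S(N)(=O)=O)cc2)c1`) gives 81000 nM, and compound 2 (`Cc1ccccc1C1CC(c2ccc(OCc3ccccc3)cc2)=NN1c1ccc(S(N)(=O)=O)cc1`) gives 100000 nM. Compound 2 and compound 3 lie within the scatter of each other at the upper end of these numbers, while the gap between compound 2 and compound 1 goes beyond the scatter.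

Compound 4 (`NS(=O)(=O)c1ccc(N2N=C(c3ccc(OCc4ccccc4)cc3)CC2c2ccc(Cl)cc2)cc1`) has yet to be measured. It has 4-chlorophenyl in place of 2-methylphenyl on a saturated ring carbon of compound 2 (4-chlorophenyl in place of 2-methylphenyl on a saturated ring carbon). For the measured compounds named here, no measured pair differs in only one place, so the data show no direct precedent for this change. A small downward move in this assay is expected, with nothing beyond the scatter. The expectation leans downward because compound 1 at 28000 nM shows that a compound of this set can sit well under compound 2. The expected change is a 1.7-fold lower number from compound 2 to compound 4 (0.22 log units; within the scatter). For compound 4 the estimated value is 60000 nM, within an expected range of 25000 nM to 120000 nM.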

Compound 4, half-maximal cytotoxic concentration: 82000 nM
Compound 4: the middle estimate sits 1.4-fold (0.14 log units) below what was measured; measured number inside the range.
By their numbers in this assay, from the lowest: compound 1; then compounds 3, 4 and 2 (each within the scatter of the next).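

In this assay, for the compounds shown here, the first comparison in this set that differs in only one place gives a 1.2-fold lower number from compound 2 to compound 4 (0.09 log units; within the scatter) for 4-chlorophenyl in place of 2-methylphenyl on the saturated ring carbon. At this position, then, the two groups cannot be told apart in this assay, even though the substituent on the phenyl ring changes in both identity and placement. No supporting measurement bears on this result.

This single step says nothing about groups of another kind on this ring carbon, such as an aminomethyl group, a carboxylic acid or a longer alkyl chain. It also leaves open whether 4-chlorophenyl would behave the same way with a different group elsewhere on the shared core, and what sets compound 1 apart at 28000 nM remains unresolved.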